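Trifluoromethyl in Place of Methoxy on the Shared Core

This account rests on a few compounds, and the source may have more. Where it says the series, first, only, none or still open, it means among the compounds named here.

Compound 1 `Cc1c(C(=O)Nc2c(F)cc(-c3cccc(F)c3)cc2F)nc2ccc(F)cc2c1C(=O)O` carries a fluoro on the shared core, and in a functional assay on A-375 cells (Homo sapiens) for antiproliferative activity, read by MTT assay, with a stated time of 24 h, tested at 0.41 ug/mL (on this read-out lower numbers stand for a weaker effect and higher numbers for a stronger effect at the one concentration tested), compound 1 gives 3.02%. Compound 2 `COc1ccc2nc(C(=O)Nc3c(F)cc(-c4cccc(F)c4)cc3F)c(C)c(C(=O)O)c2c1` bears a methoxy on that aromatic carbon instead, and in this assay compound 2 gives 3.87%, the highest of the two numbers, although the step of a number 0.9 percentage points higher from compound 1 to compound 2 (within the scatter) lies within the scatter, so no order between the two is claimed. Compound 3 `Cc1c(C(=O)Nc2c(F)cc(-c3cccc(F)c3)cc2F)nc2ccc(C(F)(F)F)cc2c1C(=O)O` differs from compound 2 in one place: trifluoromethyl in place of methoxy on an aromatic carbon. Among the compounds with values here, no measured step exchanges methoxy for trifluoromethyl; the only step at hand, a number 0.9 percentage points higher from compound 1 to compound 2 (within the scatter), shows that swapping one group on this aromatic carbon left the read-out essentially unchanged. The step of a number 0.6 percentage points higher from compound 2 to compound 3 (within the scatter) is accordingly expected to stay within the scatter. The estimate for compound 3 in this assay is 4.5%, with a range from -5% to 14%.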

Compound 3, a percentage reported as inhibition, at one concentration (the size of the read-out at that concentration, not a potency): 7.82%
Compound 3: the middle estimate sits 3.3 percentage points below what was measured, and the stated range covers the measured number.
By their numbers in this assay, from the lowest: compounds 1, 2 and 3 (each within the scatter of the next).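

With trifluoromethyl on this aromatic carbon, the steps in this assay are a number 4 percentage points higher from compound 2 to compound 3 (within the scatter) and a number 4.8 percentage points higher from compound 1 to compound 3 (within the scatter), so fluoro, methoxy and trifluoromethyl all give numbers within the scatter of one another at this one place. Trifluoromethyl brings four heavy atoms where methoxy had two, and among these three compounds that exchange makes no readable difference. No measurement in hand accounts for this result.

What the compounds shown leave open is whether an amine, a hydroxyl or a longer chain such as propyl on this carbon would carry the read-out beyond the scatter. They also leave open whether the same picture would hold for these three compounds at another concentration.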